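The source may report more compounds than this note shows. Statements on the series, on what has been measured and on what is new or still open speak of the compounds shown alone.

Measured compounds, with their results in a functional assay on PC-3 cells (Homo sapiens) for antiproliferative activity, read by MTT assay, with a stated time of 72 h; a higher number here means a weaker inhibitor, a lower number a stronger inhibitor:
- compound 1 `CC/C=C/C(=O)Nc1cc2c(N3CCCc4ccccc43)ncnc2cc1OC` gives 6310 nM
- compound 2 `CCC/C=C/C(=O)Nc1cc2c(N3CCCc4ccccc43)ncnc2cc1OC` gives 2240 nM
- compound 3 `COc1cc2ncnc(N3CCCc4ccccc43)c2cc1NC(=O)/C=C/CN1CCCCC1` gives 5780 nM

Among these three, compound 3 stands second highest in this assay. Its number sits beside that of compound 1, with a 1.1-fold lower number from compound 1 to compound 3 (0.04 log units; within the scatter), whereas compound 2 is set apart from it by a 2.6-fold higher number from compound 2 to compound 3 (0.41 log units; beyond the scatter).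

Compound 4 `COc1cc2ncnc(N3CCCc4ccccc43)c2cc1NC(=O)/C=C/CN1CCN(C)CC1` differs from compound 3 in one place: 4-methylpiperazin-1-yl in place of piperidin-1-yl on a saturated chain carbon bound to a double-bonded chain carbon.

Within the data shown here, two measured steps touch the same saturated chain carbon. Replacing methyl there by piperidin-1-yl gave a 1.1-fold lower number from compound 1 to compound 3 (0.04 log units; within the scatter), and replacing ethyl by piperidin-1-yl gave a 2.6-fold higher number from compound 2 to compound 3 (0.41 log units; beyond the scatter). Both show that groups of quite different shape at this position move the number only a little, and neither covers the exchange of one ring amine for another. For compound 4 the expected change is therefore none beyond the scatter, with a 1.2-fold lower number from compound 3 to compound 4 (0.06 log units; within the scatter), and compound 4 is estimated at 5000 nM, in a range from 2000 nM to 15000 nM.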

Compound 4, half-maximal inhibitory concentration: 6260 nM
Compound 4: middle estimate off by 1.3-fold (0.10 log units), on the low side; the measured number falls inside the stated range.
By their numbers in this assay, from the lowest: compound 2; then compounds 3, 4 and 1 (each within the scatter of the next).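

In this assay, swapping one ring amine for another on this saturated chain carbon, piperidin-1-yl for 4-methylpiperazin-1-yl, gives no change that stands out from the scatter (a 1.1-fold higher number from compound 3 to compound 4 (0.03 log units; within the scatter)). Compound 4 also reads alike with the methyl-ended chain (a 1.0-fold lower number from compound 1 to compound 4 (0.00 log units; within the scatter)), while the ethyl-ended chain remains apart (a 2.8-fold higher number from compound 2 to compound 4 (0.45 log units; beyond the scatter)), so among these compounds only compound 2 stands out. Nothing measured here offers a reason for this.

The compounds shown leave open whether morpholin-4-yl, pyrrolidin-1-yl or an open-chain amine such as dimethylamino would read the same at this carbon. They also leave open whether a chain longer than that of compound 2 would lower the number further.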